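Replacing the Azepane Amide with a Hydrazide

The compounds below may be only part of what the source reports. "The series", "measured", "known", "first", "only" and "open" are said of these compounds alone.

Three compounds share one core and differ only in the group on the carbonyl carbon. In an assay on isolated protein for inhibition of alkaline phosphatase, tissue-nonspecific isozyme (Homo sapiens) (on this read-out lower numbers stand for stronger inhibition and higher numbers for weaker inhibition), compound 1 `CC(C)NC(=O)c1cc(-c2ccc(Cl)cc2Cl)n[nH]1` gives 51 nM, compound 2 `CC(C)(C)NC(=O)c1cc(-c2ccc(Cl)cc2Cl)n[nH]1` gives 398 nM, and compound 3 `O=C(c1cc(-c2ccc(Cl)cc2Cl)n[nH]1)N1CCCCCC1` gives 1450 nM. Compound 3 thus has the highest number of the three, which here means the weakest inhibition; its nearest neighbour is compound 2, and the gap between them, a 3.6-fold higher number from compound 2 to compound 3 (0.56 log units; beyond the scatter), is beyond the scatter. The step of a 28-fold higher number from compound 1 to compound 3 (1.45 log units; beyond the scatter) is larger still.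

Compound 4 `NNC(=O)c1cc(-c2ccc(Cl)cc2Cl)n[nH]1` has not yet been measured in this assay. Its change from compound 3 is aminoamino in place of azepan-1-yl on a carbonyl carbon. Both measured steps that end at compound 3 bear on this: removing the azepan-1-yl group in favour of a smaller amide-type substituent went with lower numbers, by a 3.6-fold higher number from compound 2 to compound 3 (0.56 log units; beyond the scatter) and by a 28-fold higher number from compound 1 to compound 3 (1.45 log units; beyond the scatter) read in reverse. A smaller group with two hydrogen-bond donors entering the same place is therefore expected to give a large step downward, a 15-fold lower number from compound 3 to compound 4 (1.16 log units; beyond the scatter), so compound 4 is estimated at 100 nM, within a range from 20 nM to 600 nM.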

Compound 4, half-maximal inhibitory concentration: 44 nM
Estimate against measurement, compound 4: 2.3-fold (0.36 log units) above, and the stated range covers the measured number.
By their numbers in this assay, from the lowest: compounds 4 and 1 (each within the scatter of the next); then compound 2; then compound 3.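

Swapping azepan-1-yl for aminoamino on the carbonyl carbon brings a large drop in the number (a 33-fold lower number from compound 3 to compound 4 (1.52 log units; beyond the scatter)), so in this assay this place accepts a group with no ring and no carbon at all. Amino in place of isopropyl on the amide-type nitrogen makes no difference that can be read (a 1.2-fold lower number from compound 1 to compound 4 (0.06 log units; within the scatter)), which means the isopropyl carbons are not needed to reach the level of compound 1. Amino in place of tert-butyl gives a clear step down (a 9.0-fold lower number from compound 2 to compound 4 (0.96 log units; beyond the scatter)), leaving compound 2 and compound 3 apart from the other two compounds.

As far as these compounds go, whether the second nitrogen itself matters stays open: a plain primary amide, or a methylamino or ethylamino group on the same carbonyl carbon, would separate its presence from a mere loss of carbon atoms. Nothing here gives a measured reason for the size of any of these steps.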